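This account rests on a few compounds, and the source may have more. Where it says the series, first, only, none or still open, it means among the compounds named here.

Of the compounds shown here, three have been tested in a functional assay on RD cells (Homo sapiens) for inhibition, read by MTT assay, with a stated time of 72 h; a lower number here means a stronger inhibitor, a higher number a weaker inhibitor. Compound 1, `CN1C(=O)N(c2ccccc2)C2NC(=S)N(/N=C/C=C/c3ccccc3)C21`, gives 1690 nM. Compound 2, `CCN1C(=O)N(c2ccccc2)C2NC(=S)N(/N=C/C=C/c3ccccc3)C21`, carries the change methyl in place of hydrogen on a saturated chain carbon bound to an amide-type nitrogen in a ring and gives 470 nM. That single change produced a 3.6-fold lower number from compound 1 to compound 2 (0.56 log units; beyond the scatter). Compound 3, `CCN1C(=O)N(CC)C2C1N=C(SC)N2/N=C/C=C/c1ccccc1[N+](=O)[O-]`, belongs to a different part of the series; how its core differs from that of compound 1 is not broken down here. In this assay compound 3 gives 41900 nM, which stands far from the other two numbers.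

Compound 4, `CCSC1=NC2C(N(CC)C(=O)N2CC)N1/N=C/C=C/c1ccccc1[N+](=O)[O-]`, is the one still to be measured. It differs from compound 3 by methyl in place of hydrogen on a saturated chain carbon bound to a sulfur. Among the measured compounds shown here, this is the same kind of change as the one from compound 1 to compound 2, a single added carbon that turns a methyl into an ethyl, but it is not the same change: in the measured pair the added carbon sits on a saturated chain carbon bound to an amide-type nitrogen in a ring, whereas in compound 4 it sits on a saturated chain carbon bound to a sulfur. For the measured compounds named here, with only one measured example of such a step, and at a different place, the outcome for compound 4 is expected to be of roughly similar size or smaller, because the measured step was a 3.6-fold lower number from compound 1 to compound 2 (0.56 log units; beyond the scatter) and nothing shows how the sulfur-bound position responds. Compound 4 is therefore expected to give about 20000 nM, with a plausible range from 5000 nM to 70000 nM. That estimate corresponds to an expected step of a 2.1-fold lower number from compound 3 to compound 4 (0.32 log units; beyond the scatter).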

Compound 4, half-maximal inhibitory concentration: 2450 nM
Compound 4: middle estimate off by 8.2-fold (0.91 log units), on the high side, outside the stated range (below it).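

In this assay, turning the methylsulfanyl group of compound 3 into the ethylsulfanyl group of compound 4 gave a 17-fold lower number from compound 3 to compound 4 (1.23 log units; beyond the scatter). Both single-carbon additions lowered the number, but they did not do so by the same amount: the same change on two cores in this assay, a 3.6-fold lower number (0.56 log units; beyond the scatter) from compound 1 to compound 2 and a 17-fold lower number (1.23 log units; beyond the scatter) from compound 3 to compound 4, 4.8-fold (0.68 log units) apart, beyond the scatter of two such steps. This shows that the size of a step measured on one core cannot simply be carried over to another core in this series, although the direction was shared in these two pairs; it does not show why the sizes differ, since the two steps differ both in the core and in the place of the added carbon, a saturated chain carbon bound to an amide-type nitrogen in a ring in one case and a saturated chain carbon bound to a sulfur in the other.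

The compounds shown leave open whether a longer chain on the sulfur, such as propyl or butyl, would lower the number further or raise it again. They also leave open how an amine or a carboxylic acid at the end of that chain would read in this assay, and whether adding the same carbon at one place on both cores would give matching steps.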